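Hydroxy to methoxy: what to expect of compound 4

The source may hold more compounds than are shown below. What is called first, only, known or untested is meant among the compounds shown, and "the series" means these compounds.

Measured in an ADME assay on Vero cells (Chlorocebus sabaeus) for cytotoxicity, read by MTT assay, with a stated time of 72 h; a higher number here means that more compound is tolerated, a lower number that less compound is tolerated:
- compound 1 `COc1c(N2C[C@H]3CCCN(C(=O)Cn4cc(CN5C(=O)C(=O)c6cccc(F)c65)nn4)[C@H]3C2)c(F)cc2c(=O)c(C(=O)O)cn(C3CC3)c12`: 32 ug/mL
- compound 2 `COc1c(N2C[C@H]3CCCN(C(=O)Cn4cc(CN5C(=O)/C(=N/O)c6ccccc65)nn4)[C@H]3C2)c(F)cc2c(=O)c(C(=O)O)cn(C3CC3)c12`: 32 ug/mL
- compound 3 `COc1c(N2C[C@H]3CCCN(C(=O)Cn4cc(CN5C(=O)/C(=N/O)c6cccc(F)c65)nn4)[C@H]3C2)c(F)cc2c(=O)c(C(=O)O)cn(C3CC3)c12`: 16 ug/mL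

Compound 3, at 16 ug/mL, lies within the scatter of both other compounds, so these numbers do not separate the three.

The next compound is compound 4 `CO/N=C1/C(=O)N(Cc2cn(CC(=O)N3CCC[C@@H]4CN(c5c(F)cc6c(=O)c(C(=O)O)cn(C7CC7)c6c5OC)C[C@@H]43)nn2)c2c(F)cccc21`, still to be measured in this assay. It differs from compound 3 by one small change: methyl in place of hydrogen on an oxygen. In words, a methyl takes the place of a hydrogen on an oxygen whose other neighbour is a double-bonded nitrogen, turning a hydroxy into a methoxy.

Within the data shown here, no measured pair shows this exact change, so the evidence is indirect. Exchanging one whole group for another gave no change at the digits printed from compound 1 to compound 2 (within the scatter). Adding a single fluoro gave a 2.0-fold lower number from compound 2 to compound 3 (0.30 log units; within the scatter). Among these three compounds, then, neither change moved the number beyond the scatter. A similar result is the reasonable expectation for a single added methyl, though the data cannot confirm it.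

The expected change is a 1.5-fold higher number from compound 3 to compound 4 (0.18 log units; within the scatter), which means no step beyond the scatter is anticipated.

For compound 4 the estimated value is 24 ug/mL.

The expected range for compound 4 runs from 8 ug/mL to 64 ug/mL.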

Compound 4, half-maximal cytotoxic concentration: 16 ug/mL
Compound 4: the middle estimate sits 1.5-fold (0.18 log units) above what was measured; low and high end bracket the measured number.
By their numbers in this assay, from the lowest: compounds 3, 4, 1 and 2 (each within the scatter of the next).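

In this assay, turning the hydroxy into a methoxy, on an oxygen whose other neighbour is a double-bonded nitrogen, gave no change at the digits printed from compound 3 to compound 4 (within the scatter). Among these compounds, this is the first direct reading at this oxygen, since the earlier steps exchanged a whole group or added a fluoro on an aromatic carbon: here the hydrogen on the oxygen gives way to a methyl, and the number stays within the scatter for this pair of compounds. No measurement shown here accounts for this result, so it stands as an observation about one small change and not as an explanation.

Open, going by these compounds, is how far this tolerance reaches, since a single methyl says little about a longer chain such as an ethyl or a benzyl on the same oxygen, or about a chain that ends in an amine or a carboxylic acid. Also open, on these data alone, is whether the methyl would give the same reading with hydrogen in place of the fluoro on the aromatic carbon, as in compound 2, because this step was read only with that fluoro present.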